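This account rests on a few compounds, and the source may have more. Where it says the series, first, only, none or still open, it means among the compounds named here.

Values in an ADME assay on NIH3T3 cells (Mus musculus) for cytotoxicity; on this read-out higher numbers stand for an effect only at larger amounts of compound and lower numbers for an effect already at smaller amounts:
- compound 1 `c1ccc(-c2cccc(Oc3cccc(Cn4ccnc4)c3)c2)cc1`: 34000 nM
- compound 2 `Cc1ccccc1Oc1cccc(Cn2ccnc2)c1`: 79300 nM
- compound 3 `Cc1cc(Oc2cccc(Cn3ccnn3)c2)cc(C)c1Cl`: 66800 nM

All three values sit at the high end of the concentrations reported here, so each compound shows its effect only at large amounts. At 66800 nM, compound 3 lies within the scatter of both other compounds, so no order can be drawn between it and either of them.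

The next compound to be read in this assay is compound 4 `Cc1cc(Oc2cccc(Cn3cncn3)c2)cc(C)c1Cl`. It has the same atoms as compound 3, joined differently: 1H-1,2,4-triazol-1-yl in place of 1H-1,2,3-triazol-1-yl on a saturated chain carbon bound to an aromatic carbon. 1H-1,2,4-triazol-1-yl stands in place of 1H-1,2,3-triazol-1-yl on a saturated chain carbon bound to an aromatic carbon.

For the measured compounds named here, no measured pair differs in one place, so the data give no direct guide to the size of this change. The expectation rests on the close agreement of compound 3 at 66800 nM with compound 2 at 79300 nM. The expected result is a 1.0-fold lower number from compound 3 to compound 4 (0.01 log units; within the scatter), which would be no shift beyond the scatter in either direction.

For compound 4 the estimated value is 65000 nM, with an expected range of 33000 nM to 125000 nM.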

Compound 4, half-maximal effective concentration: 75900 nM
The estimate for compound 4 lay 1.2-fold (0.07 log units) below the measured number; the measured number falls inside the stated range.
By their numbers in this assay, from the lowest: compounds 1, 3, 4 and 2 (each within the scatter of the next, the first and the last beyond it).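

In this assay, for the compounds shown here, 1H-1,2,4-triazol-1-yl in place of 1H-1,2,3-triazol-1-yl on a saturated chain carbon bound to an aromatic carbon gives a 1.1-fold higher number from compound 3 to compound 4 (0.06 log units; within the scatter), and this is the first pair that differs in one place. At this position, then, rearranging the same atoms within the triazole, with the counts of hetero atoms and hydrogen-bond acceptors the same on both sides, does not separate the two compounds on this read-out, so on this core the two triazoles cannot be told apart here. Nothing at hand offers an explanation for this result.

Going by these compounds alone, this single pair leaves open whether the two triazoles would also read alike on a core other than the one shared by this pair. It also leaves open whether a group of another kind at this position, such as an amine or a carboxylic acid, or a longer chain carrying the triazole, would move the number beyond the scatter.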